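This account rests on a few compounds, and the source may have more. Where it says the series, first, only, none or still open, it means among the compounds named here.

Measured compounds in a functional assay on isolated protein for antagonist activity at C-C chemokine receptor type 9 (Homo sapiens), read by calcium flux, with a stated time of 10 min; a lower number here means a stronger inhibitor, a higher number a weaker inhibitor:

compound 1 `COc1ccnc(-c2cc(Cl)ccc2NS(=O)(=O)c2ccc(C(C)(C)C)cc2)c1`: 2500 nM
compound 2 `COc1cccnc1-c1cc(Cl)ccc1NS(=O)(=O)c1ccc(C(C)(C)C)cc1`: 958 nM
compound 3 `CC(C)(C)c1ccc(S(=O)(=O)Nc2ccc(Cl)cc2-c2ncncc2N)cc1`: 3.2 nM

Compound 3 gives the lowest number of the three. Compound 2 stands nearest, with a 300-fold lower number from compound 2 to compound 3 (2.48 log units; beyond the scatter), and compound 1 furthest, with a 780-fold lower number from compound 1 to compound 3 (2.89 log units; beyond the scatter). Compound 4 `CN(C)c1ncnc(-c2cc(Cl)ccc2NS(=O)(=O)c2ccc(C(C)(C)C)cc2)c1O` has not yet been measured. It differs from compound 3 in one place: a group of 10 heavy atoms (6 carbon, 3 nitrogen, 1 oxygen; one six-membered aromatic ring with 2 hetero atoms) in place of a group of 7 heavy atoms (4 carbon, 3 nitrogen; one six-membered aromatic ring with 2 hetero atoms), on an aromatic carbon. Two of the measured steps bear on this carbon, since both exchanged the ring attached there: a 780-fold lower number from compound 1 to compound 3 (2.89 log units; beyond the scatter) and a 300-fold lower number from compound 2 to compound 3 (2.48 log units; beyond the scatter), both large. The third step, a 2.6-fold lower number from compound 1 to compound 2 (0.42 log units; beyond the scatter), only moved a group within that ring and was modest. In compound 4 the ring at this carbon is again a six-membered aromatic ring with two hetero atoms, as in compound 3, but it carries more atoms and one more hydrogen-bond acceptor. The measured steps show that the identity of this ring matters greatly, yet none shows what adding to it does; the modest step from compound 1 to compound 2 hints that changes within a ring of the same kind are smaller. A moderate rise from compound 3, within a wide band, is therefore expected, as a 6.3-fold higher number from compound 3 to compound 4 (0.80 log units; beyond the scatter). Compound 4 is estimated at 20 nM in this assay, with a range of 3 nM to 150 nM.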

Compound 4, half-maximal inhibitory concentration: 9 nM
Compound 4: the middle estimate sits 2.2-fold (0.35 log units) above what was measured; the range from low to high includes it.
By their numbers in this assay, from the lowest: compound 3; then compound 4; then compound 2; then compound 1.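

In this assay, the ring on this aromatic carbon tolerates a larger set of attached groups, a dimethylamino and a hydroxyl group in place of an amino group, at only a modest cost: a 2.8-fold higher number from compound 3 to compound 4 (0.45 log units; beyond the scatter). Until now, compound 3 was the only example of a low number, but the comparison with the two methoxypyridine compounds shows that it is not alone, with a 110-fold lower number from compound 2 to compound 4 (2.03 log units; beyond the scatter) and a 280-fold lower number from compound 1 to compound 4 (2.44 log units; beyond the scatter), both large steps, so among these four compounds both rings with two hetero atoms give far lower numbers than both rings with one, and none goes against this. Nothing measured here explains why these steps have the sizes they do.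

Compound 4 brings the dimethylamino and hydroxyl groups together, and no compound shown carries one without the other, so the share of each in the modest rise stays open. Also open, going by these compounds, is how the number would respond if this ring carried a morpholine ring or a carboxylic acid instead.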